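The source may report more compounds than this note shows. Statements on the series, on what has been measured and on what is new or still open speak of the compounds shown alone.

Of the compounds shown here, two sharing one core have so far been tested in a functional assay on HepG2 cells (Homo sapiens) for cytotoxicity, read by MTT assay, with a stated time of 48 h; a lower number here means a stronger inhibitor, a higher number a weaker inhibitor. Compound 1 `O=C1/C(=C\c2ccc(O)cc2)S/C(=N/c2ccccc2)N1Cc1ccncc1` gives 11800 nM, and compound 2 `COc1cc(/C=C2/S/C(=N/c3ccccc3)N(Cc3ccncc3)C2=O)ccc1O` gives 28600 nM, which is the higher number of the pair and marks the weaker inhibitor of the two.

The next structure, compound 3 `Cc1ccc(/C=C2/S/C(=N/c3ccccc3)N(Cc3ccncc3)C2=O)s1`, has not yet been measured. It has 5-methylthiophen-2-yl in place of 4-hydroxy-3-methoxyphenyl on a double-bonded chain carbon bound to a double-bonded ring carbon.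

For the measured compounds named here, only one measured step bears on this change, and only in part, since no thiophene has been tested. Compound 3 has no methoxy, so that step, a 2.4-fold higher number from compound 1 to compound 2 (0.38 log units; beyond the scatter) for methoxy in place of hydrogen on an aromatic carbon, points to a modest move towards a lower number in this assay, and quite possibly to none beyond the scatter.

The estimated value for compound 3 is 19000 nM, with an expected range from 7500 nM to 48000 nM. The expected change is a 1.5-fold lower number from compound 2 to compound 3 (0.18 log units; within the scatter).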

Compound 3, half-maximal inhibitory concentration: 23100 nM
For compound 3 the middle estimate is 1.2-fold (0.08 log units) below the measured one, within the range that was stated.
By their numbers in this assay, from the lowest: compounds 1, 3 and 2 (each within the scatter of the next, the first and the last beyond it).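

In this assay, putting 5-methylthiophen-2-yl in place of 4-hydroxy-3-methoxyphenyl on a double-bonded chain carbon bound to a double-bonded ring carbon gives a 1.2-fold lower number from compound 2 to compound 3 (0.09 log units; within the scatter). The six-membered aromatic ring of carbon can therefore be exchanged here for a five-membered one holding sulfur, with the hydrogen-bond donor gone, and no change shows beyond the scatter; set against the 4-hydroxyphenyl group, the same entering group gives a 2.0-fold higher number from compound 1 to compound 3 (0.29 log units; within the scatter), which also stays within the scatter, so compound 3 cannot be separated from either of the other two, even though those two are separated from each other. Nothing measured on these compounds accounts for this result.

On these data alone, with all three compounds carrying an aromatic ring at this position, it remains open whether the position stays this undemanding for a ring bearing a carboxylic acid or an amine, or for an open alkyl chain with no ring at all. It is also open what the methyl on the thiophene contributes, since a thiophene without it is not among the compounds shown.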